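The source may report more compounds than this note shows. Statements on the series, on what has been measured and on what is new or still open speak of the compounds shown alone.

Working notes on the series. Compound 1 `COc1ccc(-n2ccnc2SCC(=O)Nc2ccccc2C)cc1` and compound 2 `COc1ccc(-n2ccnc2SCC(=O)Nc2ccccc2F)cc1` differ in one place. In an ADME assay on MT4 cells (Homo sapiens) for cytotoxicity, read by MTT assay (on this read-out higher numbers stand for lower toxicity in this test and lower numbers for higher toxicity in this test), compound 1 gives only a limit, > 353000 nM. In this assay compound 2 also gives only a limit, >= 41900 nM, so compound 2 stands at a limit, as does the other value shown. The step that the two limits leave unreadable from compound 1 to compound 2 cannot be sized. Compound 3 `COc1ccc(-n2ccnc2SCC(=O)Nc2ccc(C)cc2Br)cc1` is not yet measured; it differs from compound 2 by 2-bromo-4-methylphenyl in place of 2-fluorophenyl on an amide-type nitrogen. Among the compounds with values here, no measured step bears on this change, and no step beyond the scatter is expected, so a step that the limit leaves unreadable from compound 2 to compound 3 is the estimated step. Compound 3 is expected to give about 100000 nM in this assay, between 20000 nM and 400000 nM, quite possibly again as a limit.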

Compound 3, half-maximal cytotoxic concentration: 25800 nM
Beside the measured number, compound 3's estimate is 3.9-fold (0.59 log units) above it; measured number inside the range.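

Within the data shown here, compound 3 gives the only value shown here that is not a limit, so this position on the amide-type nitrogen can bring the number in this assay down to a readable value. 2-Bromo-4-methylphenyl in place of 2-methylphenyl gives an at least 13-fold lower number from compound 1 to compound 3 (1.13 log units; beyond the scatter), while in place of 2-fluorophenyl it gives an at least 1.6-fold lower number from compound 2 to compound 3 (0.21 log units; that floor lies within the scatter). That second size remains only a floor because compound 2 stands at a limit: the limit of >= 41900 nM in this assay, at which 1 of the 3 values shown sits.

The compounds shown do not separate the bromine from the methyl in this change. From the compounds shown here alone, how an amine or a carboxylic acid on this phenyl ring would read also stays open.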